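Swapping Cyano for Fluoro on the Sulfone Phenyl Ring

The source may report more compounds than this note shows. Statements on the series, on what has been measured and on what is new or still open speak of the compounds shown alone.

Compound 1 `COCC1CCN(c2c(S(=O)(=O)c3ccc(F)cc3)cnc3cc(F)ccc23)CC1` gives 76.1%.
Compound 2 `Cc1ccc2ncc(S(=O)(=O)c3cccc(C#N)c3)c(N3CCC(C)CC3)c2c1` gives 52%.
Compound 3 `COc1ccc2ncc(S(=O)(=O)c3cccc(C#N)c3)c(N3CCC(C)CC3)c2c1` gives 90%.

All three were tested in an assay on isolated protein for displacement of a labelled ligand from metabotropic glutamate receptor 5 (Homo sapiens), with a stated time of 60 min, tested at 1 uM; on this read-out lower numbers stand for less inhibition and higher numbers for more inhibition at the one concentration tested (going by the name of the read-out). Compound 2 stands lowest of the three numbers, with compound 1 and compound 3 both higher by more than the usual scatter. Among the compounds with values here, the only single-point step measured, a number 38 percentage points higher from compound 2 to compound 3 (beyond the scatter), comes from methoxy in place of methyl on an aromatic carbon, a different part of the shared core from the one that changes now. Compound 4 `Cc1ccc2ncc(S(=O)(=O)c3cccc(F)c3)c(N3CCC(C)CC3)c2c1` differs from compound 2 by fluoro in place of cyano on an aromatic carbon. Compound 1 also carries a fluoro on its phenyl ring, but it differs from compound 2 in several places at once, so its value shows nothing about this exchange alone. Within the data shown here, no measured step bears on the move from compound 2 to compound 4, so no shift beyond the scatter is expected in this assay. Compound 4 is therefore estimated at 52%, within a range of 25% to 80%. The expected step is no change at the digits printed from compound 2 to compound 4 (within the scatter).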

Compound 4, a percentage reported as inhibition, at one concentration (the size of the read-out at that concentration, not a potency): 94%
Compound 4: the middle estimate sits 42 percentage points below what was measured; measured number outside the range, above it.
By their numbers in this assay, from the lowest: compound 2; then compound 1; then compounds 3 and 4 (each within the scatter of the next).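

In this assay, the change from 3-cyanophenyl to 3-fluorophenyl gives a number 42 percentage points higher from compound 2 to compound 4 (beyond the scatter) while the rest of compound 2 stays the same, so this position clearly affects the read-out. The earlier compounds shown here showed a large step only at another place on the shared core, where methoxy replaced methyl, and compound 2 can now be raised by a single change at either place. Nothing measured on these compounds explains why one fluorine atom in place of the two-atom cyano group has this effect.

The compounds shown leave open whether a chloro group, an amine or a methoxy group at this same position would match fluoro. They also leave open what happens when the 3-fluorophenyl group and the methoxy group on the core are combined in one compound.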